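Swapping Fluorine for Chlorine in Two Related Pairs

The source may hold more compounds than are shown below. What is called first, only, known or untested is meant among the compounds shown, and "the series" means these compounds.

Two pairs of compounds share one small change on an aromatic ring. Compound 1 `CN(c1cc2ncc(=O)[nH]c2cc1NC(=N)NCc1ccc(F)cc1)C1CCCCC1` carries a fluoro group, and in an ADME assay on Huh-7 cells (Homo sapiens) for cytotoxicity (on this read-out higher numbers stand for weaker inhibition and lower numbers for stronger inhibition), compound 1 gives 10200 nM. Compound 2 `CN(c1cc2ncc(=O)[nH]c2cc1NC(=N)NCc1ccc(Cl)cc1)C1CCCCC1` differs from it only by chloro in place of fluoro on an aromatic carbon, and in this assay compound 2 gives 4400 nM. That exchange produced a 2.3-fold lower number from compound 1 to compound 2 (0.37 log units; beyond the scatter).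

Compound 3 `CN(c1cc2ncc(=O)[nH]c2cc1Nc1nc(-c2ccc(F)cc2)cs1)C1CCCCC1` is built on a different core; the difference between the cores of compound 1 and compound 3 is not broken down here. In this assay compound 3 gives 9920 nM, a number that sits within the usual scatter of the value of compound 1. Compound 4 `CN(c1cc2ncc(=O)[nH]c2cc1Nc1nc(-c2ccc(Cl)cc2)cs1)C1CCCCC1` has not yet been measured. It differs from compound 3 by chloro in place of fluoro on an aromatic carbon, the same change as that between compound 1 and compound 2, at the same place on the ring.

If the exchange acts on the second core as it did on the first, a modest lowering is expected, estimated as a 2.2-fold lower number from compound 3 to compound 4 (0.34 log units; beyond the scatter), resting on the earlier step of a 2.3-fold lower number from compound 1 to compound 2 (0.37 log units; beyond the scatter). For compound 4 in this assay the expected value is 4500 nM, with a likely range from 2200 nM to 9500 nM.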

Compound 4, half-maximal inhibitory concentration: 16700 nM
Estimate against measurement, compound 4: 3.7-fold (0.57 log units) below; the measured number lies above the stated range.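

In this assay, the exchange of fluoro for chloro on the second core gives a 1.7-fold higher number from compound 3 to compound 4 (0.23 log units; within the scatter), so compound 3 and compound 4 cannot be told apart, and the lowering seen on the first core does not reappear. The change therefore does not carry over unaltered from one core to the other, and the two steps differ by more than repeated measurements would account for: the same change on two cores in this assay, a 2.3-fold lower number (0.37 log units; beyond the scatter) from compound 1 to compound 2 and a 1.7-fold higher number (0.23 log units; within the scatter) from compound 3 to compound 4, 3.9-fold (0.59 log units) apart, beyond the scatter of two such steps. Among these compounds, this shows that a step read on one core cannot simply be transferred to the other, but with only two pairs it does not show why the cores part ways or how the change would behave on any further core.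

The compounds shown hold only fluoro and chloro at this place on the ring, so it remains open how a methyl group, a methoxy group or a nitrile would behave on each core. From the compounds shown here alone, it also remains open whether the two cores would differ in the same way on any other read-out.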